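The source may report more compounds than this note shows. Statements on the series, on what has been measured and on what is new or still open speak of the compounds shown alone.

Working notes on the series, read in a functional assay on LNCaP cells (Homo sapiens) for antiproliferative activity, read by propidium iodide staining, with a stated time of 96 h (on this read-out lower numbers stand for stronger inhibition and higher numbers for weaker inhibition), throughout. Compound 1 (`CC(O)(COc1ccc(S(F)(F)(F)(F)F)cc1)C(=O)Nc1ccc([N+](=O)[O-])c(C(F)(F)F)c1`) gives 100000 nM in this read-out. Going by the values given here, compound 2 (`CC(O)(COc1cccc(S(F)(F)(F)(F)F)c1)C(=O)Nc1ccc(S(F)(F)(F)(F)F)cc1`) gives 12000 nM and holds the lower of the two numbers so far. Its gap to compound 1 lies beyond the usual scatter. Among the compounds with values here, the two compounds differ in more than one place, so they offer no clean single-change step.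

Compound 3 (`CC(O)(COc1cccc(OC(F)(F)F)c1)C(=O)Nc1ccc(S(F)(F)(F)(F)F)cc1`) departs from compound 2 in one place (a group of 5 heavy atoms (1 carbon, 1 oxygen, 3 fluorine; no ring) in place of a group of 6 heavy atoms (5 fluorine, 1 sulfur; no ring), on an aromatic carbon). Trifluoromethoxy enters in place of a group of 6 heavy atoms (5 fluorine, 1 sulfur; no ring), on an aromatic carbon of a six-membered aromatic ring of carbon only, meta to a large group. Within the data shown here, no measured step covers this exchange, so the only anchor is compound 2 at 12000 nM in this assay and no direction can be argued from the data. The expected change is a 1.2-fold higher number from compound 2 to compound 3 (0.07 log units; within the scatter) and is estimated to stay within the scatter. For compound 3 the estimated value is 14000 nM (expected range 5000 nM to 40000 nM).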

Compound 3, half-maximal inhibitory concentration: 11000 nM
The estimate for compound 3 lay 1.3-fold (0.10 log units) above the measured number, within the range that was stated.
By their numbers in this assay, from the lowest: compounds 3 and 2 (each within the scatter of the next); then compound 1.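

In this assay, going by these compounds alone, trifluoromethoxy in place of the group of 6 heavy atoms (5 fluorine, 1 sulfur) on an aromatic carbon of a six-membered aromatic ring of carbon only, meta to a large group, gives a 1.1-fold lower number from compound 2 to compound 3 (0.04 log units; within the scatter), the first single-change step. At this place the two groups cannot be told apart in this read-out, even though the count of hydrogen-bond acceptors differs between them, so the group of 5 fluorine and 1 sulfur is not required here for a number of this size. No outside measurement bears on this step, which stands as an observation only.

On these data alone, the step covers one exchange at one place, so how a nitrile, an amine or a carboxylic acid on this aromatic carbon would read remains open, as does whether the two groups would also match elsewhere on the shared core. Compound 1 differs from compound 2 and compound 3 in more than one place, so its higher number cannot be assigned to any single change.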